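The source may hold more compounds than are shown below. What is called first, only, known or untested is meant among the compounds shown, and "the series" means these compounds.

In an ADME assay on L1210/0 cells (Mus musculus) for cytotoxicity, with a stated time of 48 h (a lower number here means a stronger inhibitor, a higher number a weaker inhibitor), compound 3 `OC[C@H]1C[C@@H](Cn2cnc3c(NC4CC4)ncnc32)c2ccccc21` gives > 200000 nM, which is a limit of the assay and not a number. It therefore stands at the limit of > 200000 nM in this assay, at which 2 of the 3 values shown sit. Compound 2 `OC[C@H]1C[C@@H](Cn2cnc3c(-c4ccc(Cl)cc4)ncnc32)c2ccccc21` gives a real number, 8440 nM. Among the measured compounds shown here, the one measured step, an at least 23-fold higher number from compound 2 to compound 3 (1.37 log units; beyond the scatter), is large. Compound 4 `Nc1ncnc2c1ncn2C[C@@H]1C[C@H](CO)c2ccccc21` has hydrogen in place of cyclopropyl on a nitrogen on an aromatic ring, turning cyclopropylamino into amino. For the measured compounds named here, no measured step covers this change directly. Compound 1 `Nc1ncnc2c1ncn2C[C@@H]1C[C@H](O)c2ccccc21`, which also carries amino, gives > 200000 nM, again a limit. Little change is therefore expected, and the estimated a number no higher from compound 3 to compound 4 (the limit leaves the size open) stays within the scatter. Compound 4 is expected at about 200000 nM, within an estimated range of 80000 nM to 400000 nM.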

Compound 4, half-maximal inhibitory concentration: > 200000 nM
Compound 4: a limit, no number; the forecaster's own chance of this, stated with the estimate: 75%; the middle value sits exactly at the limit.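

In this assay, among the compounds shown here, amino in place of 4-chlorophenyl gives an at least 23-fold higher number from compound 2 to compound 4 (1.37 log units; beyond the scatter), so cyclopropylamino is no longer the only nitrogen-linked group on this aromatic carbon that loses the real number seen with 4-chlorophenyl. The steps from compound 3 to compound 4 and from compound 1 to compound 4 cannot be read, since both ends are limits. Compound 4 also gives a limit, not a number, and joins the others there: the limit of > 200000 nM in this assay, at which 3 of the 4 values shown sit.

On these data alone, only compound 2 gives a real number, so what a plain phenyl or a longer alkyl chain on this aromatic carbon would give stays open.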